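A few compounds are considered here, and "the series" means these few. Any claim that something is new, unique, unknown or untested is made for them only; others in the source may bear on it.

The measured compounds and their values:
Compound 1, `CCOC(=O)c1ccc(-c2nn(Cc3ccc(Cl)cc3)c3ccccc23)cc1` — > 10000 nM
Compound 2, `CCOC(=O)c1ccc(-c2nn(Cc3ccncc3)c3ccccc23)cc1` — > 10000 nM

In a functional assay on cells (Platelet, Homo sapiens) for inhibition (a lower number here means a stronger inhibitor, a higher number a weaker inhibitor), compound 2 is reported only as > 10000 nM, which is a limit of the assay and not a number. Compound 1 likewise gives only a limit in this assay, > 10000 nM. The change from compound 1 to compound 2, pyridin-4-yl in place of 4-chlorophenyl on a saturated chain carbon bound to an aromatic nitrogen, yields a step that the two limits leave unreadable from compound 1 to compound 2, since (the limit of > 10000 nM in this assay, at which 2 of the 2 values shown sit).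

Compound 3, `CCOC(=O)c1ccc(-c2nn(-c3ccco3)c3ccccc23)cc1`, has not yet been measured. It differs from compound 2 as furan-2-yl in place of (pyridin-4-yl)methyl on an aromatic nitrogen. Within the data shown here, the only measured step, that from compound 1 to compound 2, concerns a different position and is unreadable, so no measured step speaks to the size or direction of this change in this assay. With both known compounds at the limit, compound 3 is expected to sit at or near that same limit, a step estimated as a step that the limit leaves unreadable from compound 2 to compound 3. In this assay compound 3 is therefore expected to give 15000 nM, within 3000 nM to 60000 nM.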

Compound 3, half-maximal inhibitory concentration: > 10000 nM
Compound 3: a limit, no number (the forecaster's own chance of this, stated with the estimate: 80%); the middle value lies beyond the limit too.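

Compound 3 also gives only a limit in this assay (> 10000 nM), which is not a number. No step among compound 1, compound 2 and compound 3 can be read from these results: the limit of > 10000 nM in this assay, at which 3 of the 3 values shown sit.

The compounds shown leave open whether any group on this aromatic nitrogen gives measurable inhibition in this assay and how these three compounds compare beyond the limit.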